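Moving the carbamoyl group around the pyridine ring

The source may hold more compounds than are shown below. What is called first, only, known or untested is meant among the compounds shown, and "the series" means these compounds.

Of the compounds shown here, three have been measured in an assay for inhibition of Fatty-acid amide hydrolase 1 (Rattus norvegicus); a higher number here means a weaker inhibitor, a lower number a stronger inhibitor. Compound 3 `O=C(CCc1ccc(-c2ccccc2)cc1)c1ncc(C(=O)C(F)(F)F)o1` gives 8 nM. Compound 1 `COC(=O)c1cccc(-c2cnc(C(O)CCc3ccc(-c4ccccc4)cc3)o2)n1` gives 9000 nM. Compound 2 `NC(=O)c1cccc(-c2cnc(C(O)CCc3ccc(-c4ccccc4)cc3)o2)n1` gives 20000 nM, the highest number of the three; compound 1 lies nearest to it, and compound 3 furthest. Among the compounds with values here, the only single-point step measured so far, a 2.2-fold higher number from compound 1 to compound 2 (0.35 log units; beyond the scatter), concerns the exchange of one group on the carbonyl carbon.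

Compound 4 `NC(=O)c1ccc(-c2cnc(C(O)CCc3ccc(-c4ccccc4)cc3)o2)nc1` is not yet measured. It differs from compound 2 in one place: 5-carbamoylpyridin-2-yl in place of 6-carbamoylpyridin-2-yl on an aromatic carbon. The carbamoyl group is thus shifted to another carbon of the same pyridine ring, while everything else in the molecule stays as it is.

Within the data shown here, no measured step involves a change of this kind, so there is nothing to set a direction. The expectation is therefore an unchanged number, with a wide range on both sides, and a step of no change at the digits printed from compound 2 to compound 4 (within the scatter) is estimated. For compound 4 in this assay the estimate is 20000 nM, expected to fall between 7000 nM and 60000 nM.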

Compound 4, inhibition constant: > 1000 nM
Compound 4 ended at the assay's limit; the forecaster's own chance of this, stated with the estimate: 15%; the middle value lies beyond the limit too.
By their numbers in this assay, from the lowest: compound 3; then compound 1; then compound 2.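

In this assay compound 4 gives > 1000 nM, which is a limit of the assay and not a number, so its steps from compound 1 and compound 2 cannot be read. The compounds shown leave open whether 5-carbamoylpyridin-2-yl in place of 6-carbamoylpyridin-2-yl changes the number, and in which direction.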